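Fluoro in place of nitro: notes on the series

A few compounds are considered here, and "the series" means these few. Any claim that something is new, unique, unknown or untested is made for them only; others in the source may bear on it.

In a physicochemical assay for lipophilicity, read by LC-MS, using the shake flask method, in phosphate buffer, measured as octanol-water partition, with a stated time of 2 h, at pH 7.4 (a lower number here means a more polar compound, a higher number a more lipophilic compound), compound 1 `COc1ccc(Cn2cc(CO[C@H]3O[C@H](CO)[C@@H](O)[C@H](O)[C@@H]3O)nn2)cc1` gives -0.4, compound 2 `COc1ccc(-n2cc(CO[C@H]3O[C@H](CO)[C@@H](O)[C@H](O)[C@@H]3O)nn2)cc1` gives -0.05 and compound 3 `O=[N+]([O-])c1ccc(-n2cc(CCO[C@H]3O[C@H](CO)[C@@H](O)[C@H](O)[C@@H]3O)nn2)cc1` gives -0.3, which lies within the scatter of both. The next structure is compound 4 `OC[C@H]1O[C@H](OCCc2cn(-c3ccc(F)cc3)nn2)[C@@H](O)[C@@H](O)[C@@H]1O`, and the change is fluoro in place of nitro on an aromatic carbon, para to a large group. For the measured compounds named here, no measured pair exchanges these groups. Going by the values given here, the only measured step, a number 0.35 log units higher from compound 1 to compound 2 (beyond the scatter), is modest and sits at another place, 4-methoxyphenyl in place of 4-methoxybenzyl, so it gives only a rough scale. The expected change in this assay is small and upward, not clearly beyond the scatter: a number 0.20 log units higher from compound 3 to compound 4 (within the scatter). For compound 4 the estimate is -0.1, with an expected range from -0.45 to 0.25.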

Compound 4, distribution coefficient: -0.21
Beside the measured number, compound 4's estimate is 0.11 log units above it, and the stated range covers the measured number.
By their numbers in this assay, from the lowest: compounds 1, 3, 4 and 2 (each within the scatter of the next, the first and the last beyond it).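

In this assay, for the compounds shown here, the first direct exchange at this position gives a number 0.09 log units higher from compound 3 to compound 4 (within the scatter), so 4-nitrophenyl and 4-fluorophenyl are not separated here. The hydrogen-bond acceptors counted on nitro leave and fluoro brings none, yet the two numbers stay within the scatter of each other. No supporting measurement bears on this result.

From the compounds shown here alone, whether an amine or a carboxylic acid on this aromatic carbon, para to a large group, would move the number beyond the scatter remains open. So does whether the exchange reads the same with a longer chain.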